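Swapping the aryl group on the pyrazole core of thiazole acids

A few compounds are considered here, and "the series" means these few. Any claim that something is new, unique, unknown or untested is made for them only; others in the source may bear on it.

Measured compounds:
- compound 1, `COc1cncc(-c2c(C)nn(-c3nc(-c4ccc(Cl)c(Cl)c4)c(SC(C)C)s3)c2C(=O)O)c1`: 21000 nM
- compound 2, `Cc1nn(-c2nc(-c3ccc(Cl)c(Cl)c3)c(SC(C)C)s2)c(C(=O)O)c1-c1cc(C#N)cc(C(F)(F)F)c1`: 3600 nM
- compound 3, `Cc1nn(-c2nc(-c3ccc(Cl)c(Cl)c3)c(SC(C)C)s2)c(C(=O)O)c1-c1ccncc1`: 5900 nM

These three compounds share one core and differ only in the aromatic group attached to it. In a functional assay on BJAB cells (Homo sapiens) for antiproliferative activity, with a stated time of 4 days (on this read-out higher numbers stand for an effect only at larger amounts of compound and lower numbers for an effect already at smaller amounts), compound 1 gives 21000 nM, compound 2 gives 3600 nM, and compound 3 gives 5900 nM. Among these three numbers compound 3 stands second highest: from compound 1 there is a 3.6-fold lower number from compound 1 to compound 3 (0.55 log units; beyond the scatter), while a 1.6-fold higher number from compound 2 to compound 3 (0.21 log units; within the scatter), so compound 2 and compound 3 cannot be told apart.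

Compound 4, `COc1cc(Cl)cc(-c2c(C)nn(-c3nc(-c4ccc(Cl)c(Cl)c4)c(SC(C)C)s3)c2C(=O)O)c1`, has not yet been measured. Its change from compound 3 is 3-chloro-5-methoxyphenyl in place of pyridin-4-yl on an aromatic carbon. The two steps that touch this position, a 5.8-fold lower number from compound 1 to compound 2 (0.77 log units; beyond the scatter) and a 3.6-fold lower number from compound 1 to compound 3 (0.55 log units; beyond the scatter), show that a 5-methoxypyridin-3-yl group gave the highest number, while a carbon-only ring carrying two substituents and a pyridin-4-yl group gave numbers within scatter of each other. Since the incoming 3-chloro-5-methoxyphenyl is again a carbon-only ring with two substituents, compound 4 is expected to sit near compound 2 and compound 3, with a 1.3-fold lower number from compound 3 to compound 4 (0.12 log units; within the scatter), likely within the scatter. The estimate for compound 4 is therefore 4500 nM, with a range from 1500 nM to 14000 nM.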

Compound 4, half-maximal effective concentration: 760 nM
Beside the measured number, compound 4's estimate is 5.9-fold (0.77 log units) above it, and the stated range ends above it.
By their numbers in this assay, from the lowest: compound 4; then compounds 2 and 3 (each within the scatter of the next); then compound 1.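

In this assay, within the data shown here, this position separates aromatic groups more sharply than the earlier compounds showed: the step to 3-chloro-5-methoxyphenyl is a 7.8-fold lower number from compound 3 to compound 4 (0.89 log units; beyond the scatter) and a 4.7-fold lower number from compound 2 to compound 4 (0.68 log units; beyond the scatter), so compound 2 and compound 4, though both carry a carbon-only ring with two substituents, do not behave alike. The widest gap is a 28-fold lower number from compound 1 to compound 4 (1.44 log units; beyond the scatter), and since both of these rings carry a methoxy group, that group alone does not set the number. Nothing available explains why these changes have these effects.

The compounds shown leave open what the chlorine and the methoxy group each contribute, as none carries a ring with only one of them. They also leave open how an amine or a longer ether chain would fare in place of the methoxy group.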